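Pentyl for Isopropyl: What Compound 4 Might Show

This account rests on a few compounds, and the source may have more. Where it says the series, first, only, none or still open, it means among the compounds named here.

Measured compounds:
compound 1, `CCCC(C#CC(=O)OC)O/C=C/C(=O)OC`, 270 nM
compound 2, `COC(=O)C#CC(O/C=C/C(=O)OC)C1CC1`, 250 nM
compound 3, `COC(=O)C#CC(O/C=C/C(=O)OC)C(C)C`, 450 nM

In a functional assay on HBL-100 cells (Homo sapiens) for antiproliferative activity, read by sulforhodamine B assay, with a stated time of 48 h (a higher number here means a weaker inhibitor of growth, a lower number a stronger inhibitor of growth), compound 3 stands at the top of the three numbers, yet its gaps to the other two, a 1.7-fold higher number from compound 1 to compound 3 (0.22 log units; within the scatter) and a 1.8-fold higher number from compound 2 to compound 3 (0.26 log units; within the scatter), each lie within the scatter, so the three compounds cannot be ranked. Compound 4, `CCCCCC(C#CC(=O)OC)O/C=C/C(=O)OC`, differs from compound 3 by pentyl in place of isopropyl on a saturated chain carbon bound to an oxygen on an unsaturated carbon and a triple-bonded carbon. The step bearing most directly on it is a 1.7-fold higher number from compound 1 to compound 3 (0.22 log units; within the scatter), since the propyl of compound 1 is the closest chain to pentyl; a 1.8-fold higher number from compound 2 to compound 3 (0.26 log units; within the scatter) points the same way but concerns a ring. Both are small. A step of a 1.6-fold lower number from compound 3 to compound 4 (0.19 log units; within the scatter) is therefore expected, a modest move back toward the number of compound 1. Compound 4 is estimated at 290 nM, within 140 nM to 600 nM.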

Compound 4, concentration for 50% growth inhibition: 1900 nM
For compound 4 the middle estimate is 6.6-fold (0.82 log units) below the measured one; measured number outside the range, above it.
By their numbers in this assay, from the lowest: compounds 2, 1 and 3 (each within the scatter of the next); then compound 4.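

In this assay, the position on the saturated chain carbon proves sensitive to the group it carries, which propyl, cyclopropyl and isopropyl had not revealed: a 4.2-fold higher number from compound 3 to compound 4 (0.63 log units; beyond the scatter) and a 7.6-fold higher number from compound 2 to compound 4 (0.88 log units; beyond the scatter) and a 7.0-fold higher number from compound 1 to compound 4 (0.85 log units; beyond the scatter) all lie beyond the scatter. Pentyl is thus the only group of the four that separates from the others, as a weaker inhibitor of growth. Nothing available accounts for this step. Going by these compounds, it remains open whether butyl at this place would stand with propyl or with pentyl, and how a longer chain or a phenyl ring would compare.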